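From Compound 2 to Compound 3: an Expected Step

This account rests on a few compounds, and the source may have more. Where it says the series, first, only, none or still open, it means among the compounds named here.

Of the compounds shown here, two have been measured. Compound 1 `CCCCC(=O)O[C@@H]1CO[C@H]2[C@@H]1OC[C@@H]2OC(=O)c1ccccc1OC(C)=O` carries a butyl group on one ester carbonyl, and in an ADME assay on a cell-free system (plasma, Homo sapiens) for metabolic stability, with Plasma (Rattus norvegicus) as the target, read by HPLC, at pH 7.4 (a lower number here means that the compound disappears faster, a higher number that the compound lasts longer), compound 1 gives 0.0198 h. Compound 2 `CC(=O)Oc1ccccc1C(=O)O[C@H]1CO[C@H]2[C@@H]1OC[C@H]2OC(=O)c1cccc(C)c1` has 3-methylphenyl in that place, and in this assay compound 2 gives 0.165 h, the higher of the two numbers; the step of an 8.3-fold higher number from compound 1 to compound 2 (0.92 log units; beyond the scatter) lies beyond the scatter. Compound 3 `CC(=O)Oc1ccccc1C(=O)O[C@H]1CO[C@H]2[C@@H]1OC[C@H]2OC(=O)c1ccc(-c2ccccc2)cc1` has not been measured. It differs from compound 2 in one place: 4-phenylphenyl in place of 3-methylphenyl on a carbonyl carbon. Among the compounds with values here, the only measured step that bears on this position is an 8.3-fold higher number from compound 1 to compound 2 (0.92 log units; beyond the scatter), where an aromatic group in place of butyl raised the number. Within the data shown here, no measured pair compares two different aromatic groups at this carbonyl, so the size of the present step cannot be read from the data. Both compound 2 and compound 3 carry an aromatic ring on this carbonyl. The author therefore expects a step of a 1.8-fold higher number from compound 2 to compound 3 (0.26 log units; within the scatter) that stays within or only slightly beyond the scatter, if anything upward. For compound 3 the estimate in this assay is 0.3 h, ranging from 0.1 h to 1 h.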

Compound 3, half-life: > 0.333 h
Compound 3: no number, only a limit; the forecaster's own chance of this, stated with the estimate: 5%; middle value at least 1.1-fold (0.04 log units) from the limit.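

In this assay, compound 3 has no number, only a limit of the assay: the limit of > 0.333 h in this assay, at which 1 of the 3 values shown sits.

Within the data shown here, this gives the first comparison of two aromatic groups on this carbonyl carbon, and 4-phenylphenyl in place of 3-methylphenyl gives an at least 2.0-fold higher number from compound 2 to compound 3 (0.30 log units; that floor lies within the scatter). The floor of that step therefore does not by itself separate the two groups, but it does show that 2 six-membered aromatic rings at this position did not lower the number, and the true step may be larger than its floor. Measured against the butyl group of compound 1, the same position now gives an at least 16-fold higher number from compound 1 to compound 3 (1.22 log units; beyond the scatter), so both aromatic groups shown stand clear of butyl, whereas earlier this rested on a single step.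

The compounds shown leave open how far the half-life of compound 3 lies past its limit, and with it the full size of the change from 3-methylphenyl to 4-phenylphenyl. They also leave open how a longer chain, a cyclohexyl ring, or a phenyl ring carrying an amine or a carboxylic acid would behave on this carbonyl carbon.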